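From Dimethylamino to Diethylamino in Compound 4

The compounds below may be only part of what the source reports. "The series", "measured", "known", "first", "only" and "open" are said of these compounds alone.

Measured in a functional assay on NCI-H460 cells (Homo sapiens) for cytotoxicity, read by MTT assay, with a stated time of 72 h; on this read-out higher numbers stand for weaker inhibition and lower numbers for stronger inhibition:
Compound 1 `CN(C)Cc1ccc2nc(NC(=O)N/N=C3\C(=O)Nc4ccc(Cl)cc43)sc2c1`: 1170 nM
Compound 2 `CN(C)Cc1ccc2nc(NC(=O)N/N=C3\C(=O)Nc4ccc(F)cc43)sc2c1`: 1550 nM
Compound 3 `CC1CCN(Cc2ccc3nc(NC(=O)N/N=C/c4cn(Cc5ccccc5Cl)c5ccccc45)sc3c2)CC1`: 1080 nM

Compound 1 and compound 3 both lie within the scatter of compound 2 at 1550 nM. Compound 4 `CCN(CC)Cc1ccc2nc(NC(=O)N/N=C3\C(=O)Nc4ccc(F)cc43)sc2c1` has diethylamino in place of dimethylamino on a saturated chain carbon bound to an aromatic carbon. Within the data shown here, no measured step covers this change. Among the measured compounds shown here, the only step available, a 1.3-fold higher number from compound 1 to compound 2 (0.12 log units; within the scatter), concerns fluoro in place of chloro on an aromatic carbon and stays within the scatter. Compound 3 differs from compound 2 in more than one place. The expected step, a 1.1-fold lower number from compound 2 to compound 4 (0.04 log units; within the scatter), is therefore none beyond the scatter in this assay. Compound 4 is estimated at 1400 nM, with an expected range from 650 nM to 3000 nM.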

Compound 4, half-maximal inhibitory concentration: 1060 nM
Estimate against measurement, compound 4: 1.3-fold (0.12 log units) above, and the stated range covers the measured number.
By their numbers in this assay, from the lowest: compounds 4, 3, 1 and 2 (each within the scatter of the next).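

In this assay, among these compounds, the change on this saturated chain carbon bound to an aromatic carbon gives a 1.5-fold lower number from compound 2 to compound 4 (0.17 log units; within the scatter), the first reading of any change at this place. Going from dimethylamino, with 3 heavy atoms, to diethylamino, with 5, therefore produces no difference that can be told from the scatter. No measurement is available that would explain this result. The compounds shown leave open whether a morpholine or pyrrolidine ring in place of these amines would move the number beyond the scatter. They also leave open whether diethylamino behaves alike with chloro on the core.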